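A few compounds are considered here, and "the series" means these few. Any claim that something is new, unique, unknown or untested is made for them only; others in the source may bear on it.

In a functional assay on CNE cells (Homo sapiens) for cytotoxicity, read by MTT assay, with a stated time of 72 h (a lower number here means a stronger inhibitor, a higher number a weaker inhibitor), compound 1 `COCOc1cc(/C=C/C(=O)OCC(=O)Nc2ccc(Cl)cc2)ccc1OCc1ccccc1` gives only a limit, > 200000 nM. Compound 2 `COCOc1cc(/C=C/C(=O)OCC(=O)NN2CCOCC2)ccc1OCc1ccccc1` likewise stays at a limit of > 200000 nM. Compound 3 `O=C(COC(=O)/C=C/c1ccc(O)c(O)c1)NN1CCOCC1` also reaches no number, with a limit of > 200000 nM. Compound 2 and compound 1 differ in one place, (4-chlorophenyl in place of morpholin-4-yl on an amide-type nitrogen), and the step that the two limits leave unreadable from compound 2 to compound 1 cannot be read because of the limit of > 200000 nM in this assay, at which 3 of the 3 values shown sit. The cores of compound 3 and compound 2 differ in more than one place, and that difference is not broken down here. Compound 4 `O=C(COC(=O)/C=C/c1ccc(O)c(O)c1)Nc1ccc(Cl)cc1` has not yet been measured in this assay; it stands to compound 3 as compound 1 stands to compound 2, with 4-chlorophenyl in place of morpholin-4-yl on an amide-type nitrogen. The surroundings of the change, an amide-type nitrogen whose other neighbour is a carbonyl carbon, are the same in both pairs, so it is the same change. Every measured compound sits at the limit and the earlier step gave no readable size, so the expectation for compound 4 rests on the limit shown by compound 3, > 200000 nM. The step from compound 3 to compound 4 is expected to be a step that the limit leaves unreadable from compound 3 to compound 4. Compound 4 is expected to give about 250000 nM in this assay, between 80000 nM and 1000000 nM, most likely again only as a limit.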

Compound 4, half-maximal inhibitory concentration: 89600 nM
For compound 4 the middle estimate is 2.8-fold (0.45 log units) above the measured one; the measured number falls inside the stated range.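

In this assay, as far as these compounds go, replacing morpholin-4-yl with 4-chlorophenyl on an amide-type nitrogen gives an at least 2.2-fold lower number from compound 3 to compound 4 (0.34 log units; beyond the scatter), and because one end of this step is only a limit, its full size remains unknown: the limit of > 200000 nM in this assay, at which 3 of the 4 values shown sit. On the core of compound 2 and compound 1, the same change produces no number, and that step cannot be read because both compounds remain at the limit: the limit of > 200000 nM in this assay, at which 3 of the 4 values shown sit. The change therefore gives a measured value on one core but not on the other, which shows that a readable result on one core did not appear on the second; it does not show whether the size of the step carries over, since the second step may be hidden beyond the limit.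

The compounds shown leave open whether this result is specific to 4-chlorophenyl or would also appear with another group on that nitrogen, such as unsubstituted phenyl or piperidin-1-yl. They also leave open whether a core carrying only one of the benzyloxy and methoxymethoxy groups would give a number.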